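The source may report more compounds than this note shows. Statements on the series, on what has been measured and on what is new or still open speak of the compounds shown alone.

In an in vivo ADME assay on the whole organism for pharmacokinetics, with Canis familiaris (Canis lupus familiaris) as the target, at a dose of 0.6 mg/kg by the oral route (a lower number here means that a smaller share of the oral dose reaches the circulation, a higher number that a larger share of the oral dose reaches the circulation), compound 1 `Cc1ccc([C@H](C(=O)N(C)C)N2C(=O)[C@@H](C3Cc4ccccc4C3)NC(=O)[C@H]2CC(C)C)cn1` gives 26% and compound 2 `CC[C@@H](C)[C@@H]1C(=O)N[C@H](C2Cc3ccccc3C2)C(=O)N1[C@@H](C(=O)N1CCOCC1)c1ccc(C)nc1` gives 31%, two numbers within the usual scatter of each other. Those two compounds differ in more than one place, so they say little about any single change. Compound 3 `CC[C@H](C)[C@@H]1C(=O)N[C@H](C2Cc3ccccc3C2)C(=O)N1[C@@H](C(=O)N1CCOCC1)c1ccc(C)nc1` is a much closer relative of compound 2. The two compounds have the same atoms and bonds and differ only in configuration as drawn (the two compounds have the same atoms and bonds and differ only in configuration as drawn: 1 of 4 stereo elements differ; a stereocentre at a saturated chain carbon is drawn R in compound 2 and S in compound 3): a stereocentre at a saturated chain carbon is drawn R in compound 2 and S in compound 3. Among the measured compounds shown here, no measured pair here shows a change of this kind, so the data give no direction for it. In this assay, the expected result is a number 1 percentage points lower from compound 2 to compound 3 (within the scatter), a step no larger than the scatter. For compound 3 the estimated value is 30%, within an expected range of 14% to 46%.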

Compound 3, oral bioavailability: 14%
Compound 3: middle estimate off by 16 percentage points, on the high side; low and high end bracket the measured number.
By their numbers in this assay, from the lowest: compound 3; then compounds 1 and 2 (each within the scatter of the next).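

In this assay, reversing the configuration as drawn at this one saturated chain carbon gives a number 17 percentage points lower from compound 2 to compound 3 (beyond the scatter). Among the compounds shown here, the earlier comparison involved compounds that differ in more than one place, so this is the first reading of a single change, and it shows that this stereocentre alone can shift oral bioavailability by more than the usual scatter. The step can be tied to this carbon because nothing else in the structures differs: the fact that compounds 2 and 3 differ only in the configuration as drawn

A single pair cannot tell by what route the share of the oral dose reaching the circulation falls, or whether the other three stereo elements matter as much. Nor do these compounds show how a longer chain or a carboxylic acid in place of the chain carrying this carbon would behave in this assay.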